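From 5-Methylthiophen-2-yl to 1,3-Thiazol-2-yl: Expected Tolerability

The compounds below may be only part of what the source reports. "The series", "measured", "known", "first", "only" and "open" are said of these compounds alone.

Compound 1, `Cc1ccc(CN[C@@H]2C[C@H]3C[C@@H]([C@H]2C)C3(C)C)s1`, was tested in an ADME assay on MDCK cells (Canis lupus familiaris) for cytotoxicity, read by microscopy, with a stated time of 48 h (a lower number here means that less compound is tolerated, a higher number that more compound is tolerated), where compound 1 gives 780 nM. Its companion compound 2, `C[C@H]1[C@H](NCc2cc(C3CCCC3)cs2)C[C@H]2C[C@@H]1C2(C)C`, gives 1560 nM in this assay. Compound 1 stands at the lowest of the two numbers, but the gap to compound 2 lies within the usual scatter of repeated measurements, so the two cannot be told apart on these data. Among the measured compounds shown here, no pair of measured compounds that differ in a single place is available, so no measured step exists to guide the next comparison.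

Compound 3, `C[C@H]1[C@H](NCc2nccs2)C[C@H]2C[C@@H]1C2(C)C`, has not yet been measured. It differs from compound 1 in one place: 1,3-thiazol-2-yl in place of 5-methylthiophen-2-yl on a saturated chain carbon bound to an amine nitrogen. Nothing measured here speaks to this particular exchange.

With that in mind, the step from compound 1 to compound 3 in this assay is expected to be small, if anything leaning toward a higher tolerated concentration, and is estimated as a 1.5-fold higher number from compound 1 to compound 3 (0.19 log units; within the scatter). Compound 3 is accordingly expected to give 1200 nM in this assay, with an estimated range from 500 nM to 3100 nM.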

Compound 3, minimum cytotoxic concentration: > 100000 nM
Compound 3 gave a limit, no number; the forecaster's own chance of this, stated with the estimate: 10%; middle value at least 83-fold (1.92 log units) away from the limit.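

In this assay, putting 1,3-thiazol-2-yl in place of 5-methylthiophen-2-yl on a saturated chain carbon bound to an amine nitrogen gives an at least 120-fold higher number from compound 1 to compound 3 (2.10 log units; beyond the scatter). For compound 3 the reading is a limit of the assay and not a number: the limit of > 100000 nM in this assay, at which 1 of the 3 values shown sits. Among the compounds shown here, this is the first measured step between compounds that differ in one place, and it shows that the group at this position, with the rest of the molecule unchanged, can make a large difference to how much compound the cells tolerate.

The exchange changes two things at once, since the methyl group is lost and a five-membered aromatic ring with 1 hetero atom gives way to one with 2 hetero atoms, and the compounds shown do not separate these two changes. A plain thiophen-2-yl group, without the methyl, and a 5-methyl-1,3-thiazol-2-yl group, which keeps the methyl on the new ring, would show which of the two changes goes with the step, so the cause of this large difference remains open.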